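This account rests on a few compounds, and the source may have more. Where it says the series, first, only, none or still open, it means among the compounds named here.

In a functional assay on PC-3 cells (Homo sapiens) for cytotoxicity, read by MTT assay, with a stated time of 72 h (a lower number here means a stronger inhibitor, a higher number a weaker inhibitor), three compounds built on a shared core have been tested. Compound 1 `O=C(/C=C/c1ccc([N+](=O)[O-])cc1)Nc1cc2c(Nc3ccc(F)c(Cl)c3)ncnc2cc1O[C@H]1CCOC1` gives 22800 nM and compound 3 `COc1cc2ncnc(Nc3ccc(F)c(Cl)c3)c2cc1NC(=O)/C=C/c1ccccc1[N+](=O)[O-]` gives 14300 nM. For the measured compounds named here, these are the only two numbers available, and they lie within the scatter of each other, so compound 1 cannot be separated from compound 3. Compound 2 `COc1ccc(/C=C/C(=O)Nc2cc3c(Nc4ccc(F)c(Cl)c4)ncnc3cc2OC)cc1` is reported as "not active" (no number reported), with no number attached.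

Compound 4 `O=C(/C=C/c1cc(Br)c(O)c(Br)c1)Nc1cc2c(Nc3ccc(F)c(Cl)c3)ncnc2cc1O[C@H]1CCOC1` has not yet been measured. It differs from compound 1 by a single exchange, 3,5-dibromo-4-hydroxyphenyl in place of 4-nitrophenyl on a double-bonded chain carbon bound to a double-bonded chain carbon. Going by the values given here, no measured pair isolates this exchange, so the expectation is a loose one: a modest move toward a lower number in this assay, not far beyond the scatter. A report without a number, as for compound 2, cannot be ruled out. The expected size of the change is a 2.3-fold lower number from compound 1 to compound 4 (0.36 log units; beyond the scatter). For compound 4 the estimated value is 10000 nM, with an expected range from 2500 nM to 40000 nM.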

Compound 4, half-maximal inhibitory concentration: 25500 nM
Estimate against measurement, compound 4: 2.6-fold (0.41 log units) below, and the stated range covers the measured number.
By their numbers in this assay, from the lowest: compounds 3, 1 and 4 (each within the scatter of the next).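

In this assay, for the compounds shown here, 3,5-dibromo-4-hydroxyphenyl in place of 4-nitrophenyl on a double-bonded chain carbon bound to a double-bonded chain carbon comes with a 1.1-fold higher number from compound 1 to compound 4 (0.05 log units; within the scatter), the only single-place comparison available at this position. The entering group carries bromine and a hydrogen-bond donor that the leaving group lacks, and the leaving group carries nitrogen and a double bond outside the ring, yet this difference in make-up produces no change that can be told from the scatter. Nothing measured here offers a reason for this outcome.

From the compounds shown here alone, whether an aminophenyl or a carboxylic acid at this place would move the number beyond the scatter remains open. So does the effect of a longer chain in place of the ethenyl link.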